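This account rests on a few compounds, and the source may have more. Where it says the series, first, only, none or still open, it means among the compounds named here.

Compound 1 `NC(=O)c1nc(C#Cc2ccccc2)n(COCCO)n1`: in an ADME assay on Huh-5-2 cells (Homo sapiens) for cytotoxicity (on this read-out higher numbers stand for lower toxicity in this test and lower numbers for higher toxicity in this test), compound 1 is reported only as the limit > 50 ug/mL.
Compound 2 `NC(=O)c1nc(C#Cc2cccc(F)c2)n(COCCO)n1`: in this assay compound 2 gives 29 ug/mL.
Compound 3 `NC(=O)c1nc(C#Cc2ccccc2F)n(COCCO)n1`: in this assay compound 3 is reported only as the limit > 50 ug/mL.

Compound 3 therefore stands at the top of what this assay reports, and the limit of > 50 ug/mL in this assay, at which 2 of the 3 values shown sit, shows that it shares this position with another compound; the step from compound 1 to compound 3 is a step that the two limits leave unreadable from compound 1 to compound 3. Going by the values given here, the one readable comparison with compound 3 is an at least 1.7-fold higher number from compound 2 to compound 3 (0.23 log units; that floor lies within the scatter), and the other measured step, an at least 1.7-fold lower number from compound 1 to compound 2 (0.23 log units; that floor lies within the scatter), also concerns a fluoro group on the aromatic ring.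

Compound 4 `NC(=O)c1nc(C#CC2(O)CCCCC2)n(COCCO)n1` brings a different kind of change: 1-hydroxycyclohexyl in place of 2-fluorophenyl on a triple-bonded carbon. Among the compounds with values here, none of the measured steps exchanges the aromatic ring itself, so they give no direct guide to its size. With two of three values at the limit, compound 4 is expected to sit near that limit as well, with a step of about a number no higher from compound 3 to compound 4 (the limit leaves the size open) that is not expected to go beyond the scatter. The estimate for compound 4 is 50 ug/mL, with a range from 25 ug/mL to 100 ug/mL.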

Compound 4, half-maximal cytotoxic concentration: > 50 ug/mL
Compound 4: no number, only a limit; the forecaster's own chance of this, stated with the estimate: 60%; the middle value lies on the limit itself.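

In this assay compound 4 is reported only as the limit > 50 ug/mL. The earlier compounds shown here differed only in a fluoro group on an aromatic ring, whereas here 1-hydroxycyclohexyl, a non-aromatic ring, takes the place of that aromatic ring on the triple-bonded carbon, and the result still sits at the top of what the assay reports: the limit of > 50 ug/mL in this assay, at which 3 of the 4 values shown sit. Going by these compounds alone, the one readable step is an at least 1.7-fold higher number from compound 2 to compound 4 (0.23 log units; that floor lies within the scatter), while the steps to compound 4 from compound 1 and compound 3 cannot be read, since both ends are limits.

Going by these compounds, how far compound 1, compound 3 and compound 4 lie past the limit stays open, so they cannot be ranked against one another. Also open, on these data alone, is whether an amine or a carboxylic acid on the ring at this position, or a longer chain in its place, would stay at this limit.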